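The source may hold more compounds than are shown below. What is called first, only, known or untested is meant among the compounds shown, and "the series" means these compounds.

Within the data shown here, compound 1, whose structure is `Cn1nccc1-c1cnc(NCc2c(F)ccc3c2CCO3)c2cn[nH]c(=O)c12`, is one of two compounds measured in a physicochemical assay for lipophilicity, using the shake flask method, in phosphate buffer, measured as octanol-water partition, with a stated time of 30 min, at pH 7.4; a lower number here means a more polar compound, a higher number a more lipophilic compound. In this assay compound 1 gives 2.6, and compound 2, whose structure is `COCCC(=O)Nc1cnc(NCc2c(F)ccc3c2CCO3)n2cnnc12`, gives 1.4. Of these two numbers compound 1 stands highest. The gap between compound 1 and compound 2 lies beyond the usual scatter of repeated measurements. The two compounds differ in several places at once, so no single step can be read between them.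

Compound 3, whose structure is `CN(c1ccn(C)n1)c1cnc(NCc2c(F)ccc3c2CCO3)c2cn[nH]c(=O)c12`, has not yet been measured. It differs from compound 1 in one place only: methyl(1-methyl-1H-pyrazol-3-yl)amino in place of 1-methyl-1H-pyrazol-5-yl on an aromatic carbon. Among the measured compounds shown here, with no measured step of this kind to lean on, the change from compound 1 to compound 3 is expected to move this assay little, if at all, and any step of a number 0.10 log units lower from compound 1 to compound 3 (within the scatter) is expected to stay within the scatter. Compound 3 is therefore estimated at 2.5, between 2 and 3.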

Compound 3, distribution coefficient: 2.4
Beside the measured number, compound 3's estimate is 0.10 log units above it; the measured number falls inside the stated range.
By their numbers in this assay, from the lowest: compound 2; then compounds 3 and 1 (each within the scatter of the next).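

In this assay, among these compounds, putting methyl(1-methyl-1H-pyrazol-3-yl)amino in place of 1-methyl-1H-pyrazol-5-yl on this aromatic carbon gives a number 0.20 log units lower from compound 1 to compound 3 (within the scatter), the first change here that can be read at a single place. At this position, then, a group with more heavy atoms and an added hydrogen-bond acceptor, still carrying a five-membered aromatic ring, gives a number that cannot be told apart from that of compound 1. No measurement shown here bears on why the number holds for this pair.

From the compounds shown here alone, whether a group without a ring at this position, such as a primary amine or a carboxylic acid, would also stay within the scatter remains open. So does whether this same change would read alike on a core other than that of compound 1.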